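The source may report more compounds than this note shows. Statements on the series, on what has been measured and on what is new or still open speak of the compounds shown alone.

Measured compounds:
compound 1, `C=CCOc1c(C)c(C)c2c(c1C)CCC(C)(COc1ccc(/C=C3\SC(=O)NC3=O)cc1OC)O2`, 1%;
compound 2, `C=CCOc1c(C)c(C)c2c(c1C)CCC(C)(COc1ccc(/C=C3\SC(=O)NC3=O)cc1C)O2`, 8%;
compound 3, `CC(C)=CCOc1c(C)c(C)c2c(c1C)CCC(C)(COc1ccc(/C=C3\SC(=O)NC3=O)cc1-c1ccc(F)cc1)O2`, 85%.

In a functional assay on MCF7 cells (Homo sapiens), tested at 7.5 uM (a higher number here means a weaker effect of the compound at the concentration tested, a lower number a stronger effect), compound 3 stands highest of the three numbers: compound 2 lies a number 7 percentage points higher from compound 1 to compound 2 (within the scatter) from compound 1, a step within the scatter, while compound 3 sits far above both, beyond the scatter in each case.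

Compound 4, `COc1cc(/C=C2\SC(=O)NC2=O)ccc1OCC1(C)CCc2c(C)c(OCC=C(C)C)c(C)c(C)c2O1`, has not yet been measured. It differs from compound 3 in one place: methoxy in place of 4-fluorophenyl on an aromatic carbon.

Within the data shown here, no measured step covers methoxy in place of 4-fluorophenyl on an aromatic carbon. Among the measured compounds shown here, the only measured step, a number 7 percentage points higher from compound 1 to compound 2 (within the scatter), exchanges methoxy for methyl and stays within the scatter, so it says nothing about the size of the present change. What the numbers do show is that the two compounds carrying a small group on that carbon, compound 1 and compound 2, both give low numbers in this assay, while compound 3 carries the 4-fluorophenyl and gives a high one; compound 3 also differs from them elsewhere, so the cause cannot be assigned.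

Compound 4 is expected to move strongly downward, by a number 75 percentage points lower from compound 3 to compound 4 (beyond the scatter). Compound 4 is therefore estimated at 10%, with a range from 0% to 40%.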

Compound 4, a percentage reported as activity, at one concentration (the size of the read-out at that concentration, not a potency): 54%
Beside the measured number, compound 4's estimate is 44 percentage points below it; measured number outside the range, above it.
By their numbers in this assay, from the lowest: compounds 1 and 2 (each within the scatter of the next); then compound 4; then compound 3.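

Among these compounds, the step of a number 31 percentage points lower from compound 3 to compound 4 (beyond the scatter) in this assay is the first reading of this exchange on the aromatic carbon ortho to a large group, and it shows that methoxy in place of 4-fluorophenyl lowers the number substantially when the 2-methylprop-1-en-1-yl end is held constant. The step of a number 53 percentage points higher from compound 1 to compound 4 (beyond the scatter) then shows that the far end of the molecule also matters: with methoxy held constant, 2-methylprop-1-en-1-yl in place of vinyl on the saturated chain carbon bound to an oxygen gives a large rise, so the high number of compound 3 cannot be read as a matter of the 4-fluorophenyl alone. Nothing measured here speaks to what lies behind either step.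

The compounds shown leave open how 4-fluorophenyl behaves when vinyl stands at the other end, and so whether the two changes simply add. They also leave open how a hydroxyl or a chlorine on the aromatic carbon, or a longer chain in place of 2-methylprop-1-en-1-yl, would read in this assay at this single concentration.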